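A few compounds are considered here, and "the series" means these few. Any claim that something is new, unique, unknown or untested is made for them only; others in the source may bear on it.

Working notes on the sulfonyl series, read-out in an ADME assay on MDCK cells (Canis lupus familiaris) for permeability, in the apical to basolateral direction; on this read-out lower numbers stand for lower permeability and higher numbers for higher permeability.

Measured so far:
compound 1 `O=C(NCc1ccc(S(=O)(=O)c2cc(F)cc(F)c2)cc1)c1cc2ccncc2o1`: 14 10^-6 cm/s
compound 2 `CC(C)n1cc(S(=O)(=O)c2ccc(CNC(=O)c3cc4ccncc4o3)cc2)cn1`: 14 10^-6 cm/s
compound 3 `O=C(NCc1ccc(S(=O)(=O)c2cc(F)cc(F)c2)cn1)c1cc2cnccc2[nH]1`: 8.8 10^-6 cm/s

Compound 1 and compound 2 share one core and differ in a single place: 1-isopropyl-1H-pyrazol-4-yl in place of 3,5-difluorophenyl on a sulfonyl sulfur. The step this change made in this assay is no change at the digits printed from compound 1 to compound 2 (within the scatter). Compound 3 carries a different core from compound 1; the difference between the two cores is not broken down here, and only the two values themselves can be set side by side. Compound 3 stands lowest of the three numbers, but its gap to compound 1 and to compound 2 is within the scatter, so no order among the three is claimed.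

Compound 4 `CC(C)n1cc(S(=O)(=O)c2ccc(CNC(=O)c3cc4cnccc4[nH]3)nc2)cn1` is not yet measured. It stands to compound 3 exactly as compound 2 stands to compound 1: 1-isopropyl-1H-pyrazol-4-yl in place of 3,5-difluorophenyl on a sulfonyl sulfur. The place line is the same word for word, so this is the same change, made on the core of compound 3 instead of the core of compound 1. The change occurs twice in all among these compounds, once measured and once open.

Among the compounds with values here, the expectation for compound 4 rests on the one measured instance of the change. Because no change at the digits printed from compound 1 to compound 2 (within the scatter) left the read-out unchanged within the scatter, the step from compound 3 to compound 4 is expected to be no change at the digits printed from compound 3 to compound 4 (within the scatter). Compound 4 is therefore estimated at 8.8 10^-6 cm/s in this assay, with a range from 4.5 10^-6 cm/s to 17 10^-6 cm/s expected to cover most repeats. On these data alone, whether the core of compound 3 responds to this change as the core of compound 1 did is unknown from a single precedent, which is the main uncertainty in this estimate.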

Compound 4, apparent permeability in the MDCK assay: 2.3 10^-6 cm/s
For compound 4 the middle estimate is 3.8-fold (0.58 log units) above the measured one; the whole stated range lies above it.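

In the MDCK assay, 1-isopropyl-1H-pyrazol-4-yl in place of 3,5-difluorophenyl on a sulfonyl sulfur gives a 3.8-fold lower number from compound 3 to compound 4 (0.58 log units; beyond the scatter), so in this series the outcome of this change on the core of compound 1 does not carry over to the core of compound 3, and the two instances differ: the same change on two cores in the MDCK assay, no change at the digits printed (within the scatter) from compound 1 to compound 2 and a 3.8-fold lower number (0.58 log units; beyond the scatter) from compound 3 to compound 4, 3.8-fold (0.58 log units) apart, beyond the scatter of two such steps. On the core of compound 3 the same change also shifts the read-out of a physicochemical assay for solubility, measured as kinetic solubility, with a stated time of 24 h, at pH 7.4 (a lower number here means a less soluble compound, a higher number a more soluble compound), in the direction of a higher number: the measured solubility of compound 3, 11000 nM, and of compound 4, 46000 nM, a 4.2-fold higher number (0.62 log units; beyond the scatter). In the physicochemical assay compound 3 gives 11000 nM and compound 4 gives 46000 nM. This does not show which feature of the two cores separates the two instances, as the difference between the cores is not broken down, and two instances give no rule for any further core; in the physicochemical assay the change is shown on the core of compound 3 only.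

Open, on these data alone, is which part of the difference between the two cores sets the size of the step in the MDCK assay. Also open, as far as these compounds go, is whether the read-outs of the MDCK assay and the physicochemical assay would shift in opposite directions on either core with another group on the sulfonyl sulfur, such as a cyclopropyl group or a short chain ending in an amine.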